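Sulfonate series: methoxy-to-nitro step on the chlorobenzyl analog

The source may report more compounds than this note shows. Statements on the series, on what has been measured and on what is new or still open speak of the compounds shown alone.

Three compounds of the series have been run so far in a functional assay on RS4-11 cells (Homo sapiens) for inhibition, read by CCK-8 assay, with a stated time of 48 h, tested at 20 uM; on this read-out lower numbers stand for less inhibition of growth and higher numbers for more inhibition of growth at the one concentration tested. Compound 1 `COc1ccc(S(=O)(=O)Oc2ccccc2/C=C(\C#N)C(=O)Nc2nnc(Cc3ccc(F)cc3)s2)cc1` gives 76% in this assay. Compound 2 `N#C/C(=C\c1ccccc1OS(=O)(=O)c1ccc([N+](=O)[O-])cc1)C(=O)Nc1nnc(Cc2ccc(F)cc2)s1` gives 55% in this assay. Compound 3 `COc1ccc(S(=O)(=O)Oc2ccccc2/C=C(\C#N)C(=O)Nc2nnc(Cc3ccc(Cl)cc3)s2)cc1` gives 77% in this assay.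

Two single-point changes connect them. From compound 1 to compound 2 the change is nitro in place of methoxy on an aromatic carbon, and the step in this assay is a number 21 percentage points lower from compound 1 to compound 2 (beyond the scatter). From compound 1 to compound 3 the change is chloro in place of fluoro on an aromatic carbon, and the step in this assay is a number 1 percentage points higher from compound 1 to compound 3 (within the scatter), so compound 1 and compound 3 are not told apart by this read-out.

Compound 4 `N#C/C(=C\c1ccccc1OS(=O)(=O)c1ccc([N+](=O)[O-])cc1)C(=O)Nc1nnc(Cc2ccc(Cl)cc2)s1` has not yet been measured. It differs from compound 3 by nitro in place of methoxy on an aromatic carbon. The two cores differ by chloro in place of fluoro on an aromatic carbon. The place of the methoxy-to-nitro change is described in the same words for both pairs, so this is the same change, appearing twice among the compounds shown.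

The step from compound 3 to compound 4 is expected to be about a number 21 percentage points lower from compound 3 to compound 4 (beyond the scatter), set beside the earlier a number 21 percentage points lower from compound 1 to compound 2 (beyond the scatter). This expectation rests on compound 1 at 76% and compound 3 at 77% lying within the scatter of each other, so the earlier step is taken over as it stands. For compound 4 the estimate in this assay is 56%, with a range from 43% to 69%. Among the compounds with values here, only one prior example of the change exists, so the range is kept wide.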

Compound 4, percent growth inhibition at one concentration: 66%
Compound 4: middle estimate off by 10 percentage points, on the low side; measured number inside the range.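

In this assay, nitro in place of methoxy lowers the number on both cores, here with a number 11 percentage points lower from compound 3 to compound 4 (beyond the scatter), and the two examples of this change are not told apart: the same change on two cores in this assay, a number 21 percentage points lower (beyond the scatter) from compound 1 to compound 2 and a number 11 percentage points lower (beyond the scatter) from compound 3 to compound 4, 10 percentage points apart, within the scatter of two such steps. Chloro in place of fluoro, read on the nitro compounds, gives a number 11 percentage points higher from compound 2 to compound 4 (beyond the scatter), and this step is likewise not told apart from its earlier counterpart: the same change on two cores in this assay, a number 1 percentage points higher (within the scatter) from compound 1 to compound 3 and a number 11 percentage points higher (beyond the scatter) from compound 2 to compound 4, 10 percentage points apart, within the scatter of two such steps. The methoxy-to-nitro change therefore carries from one core to the other in direction and shows no sign of depending on the core, but two pairs at one concentration do not fix the size of the step, and they neither prove nor exclude a smaller dependence hidden in the scatter.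

What the compounds shown leave open is whether the same carry-over holds for other groups on that aromatic carbon, such as an amine, a carboxylic acid or a longer alkoxy chain, or for a bromo group in place of the chloro and fluoro groups. Also open, on these data alone, is whether the order seen at the one tested concentration would hold across a full concentration range or in other cell lines.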